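Swapping a cyclopropylmethoxy for fluoro on a chromone stilbene

The compounds below may be only part of what the source reports. "The series", "measured", "known", "first", "only" and "open" are said of these compounds alone.

Two compounds share a core that carries a methoxy-bearing aromatic ring joined through a double bond to a second aromatic ring. In a functional assay on PC-3 cells (Homo sapiens) for antiproliferative activity, read by MTT assay, with a stated time of 12 h (a higher number here means a weaker inhibitor, a lower number a stronger inhibitor), compound 1, `COc1ccc2oc(/C=C/c3ccc(OC(F)(F)F)cc3)cc(=O)c2c1`, gives only a limit, > 40000 nM. Compound 2, `COc1cc(OC)c2c(=O)cc(/C=C/c3ccc(OCC4CC4)cc3)oc2c1`, likewise gives only a limit, > 40000 nM. Neither value is a number, so compound 2 stands with compound 1 at the limit of > 40000 nM in this assay, at which 2 of the 2 values shown sit, and no gap between the two can be read.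

Compound 3, `COc1cc(OC)c2c(=O)cc(/C=C/c3ccc(F)cc3)oc2c1`, has not been tested. It differs from compound 2 in one place: fluoro in place of cyclopropylmethoxy on an aromatic carbon. Among the measured compounds shown here, no measured pair shows what such a change does to potency, so the expected step that the limit leaves unreadable from compound 2 to compound 3 is none beyond the scatter of this assay. Compound 3 is therefore estimated at 60000 nM, with a range from 20000 nM to 200000 nM, most likely again reported as a limit.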

Compound 3, half-maximal inhibitory concentration: > 40000 nM
Compound 3 ended at the assay's limit; the forecaster's own chance of this, stated with the estimate: 75%; the middle value does not contradict the limit.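

In this assay, compound 2 and compound 3 each give only a limit and not a number, so no step can be read between them: the limit of > 40000 nM in this assay, at which 3 of the 3 values shown sit.

The compounds shown leave open what fluoro in place of cyclopropylmethoxy does to potency on this shared core.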